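The compounds below may be only part of what the source reports. "The series", "measured", "known", "first", "only" and "open" are said of these compounds alone.

Measured so far:
Compound 1, `CC(C)N1CCN(Cc2csc(N)c2C(=O)c2ccc(Cl)cc2)CC1`: 7.3%
Compound 2, `Nc1scc(CN2CCN(c3ccc(Cl)cc3Cl)CC2)c1C(=O)c1ccc(Cl)cc1`: -54%

The two values come from a functional assay on CHO cells with adenosine receptor A1 (Homo sapiens) as the target, read by cAMP accumulation and immunoassay, with a stated time of 6 min, tested at 1 uM; a higher number here means a weaker effect of the compound at the concentration tested, a lower number a stronger effect. Compound 2, which carries a 2,4-dichlorophenyl on the ring amine nitrogen, gives -54% and stands at the lowest of the two numbers; its nearest neighbour is compound 1. Among the compounds with values here, the one step measured so far, a number 61.3 percentage points lower from compound 1 to compound 2 (beyond the scatter), is the only guide available, and it concerns a different exchange from the one considered now.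

Compound 3, `Nc1scc(CN2CCN(c3cccc(Cl)c3Cl)CC2)c1C(=O)c1ccc(Cl)cc1`, is not yet measured. It differs from compound 2 as follows:
2,3-dichlorophenyl in place of 2,4-dichlorophenyl on an amine nitrogen in a ring
Within the data shown here, no measured step bears directly on this change: the step from compound 1 to compound 2 exchanged an isopropyl for a dichlorophenyl, whereas here one dichlorophenyl gives way to another of the same count of atoms. The expectation is therefore that the number for compound 3 stays close to that of compound 2, with a step of a number 14 percentage points higher from compound 2 to compound 3 (beyond the scatter) that may not exceed the scatter. For compound 3 the estimate is -40%, within a range from -80% to 0%.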

Compound 3, a percentage reported as activity, at one concentration (the size of the read-out at that concentration, not a potency): -57%
Beside the measured number, compound 3's estimate is 17 percentage points above it; the measured number falls inside the stated range.
By their numbers in this assay, from the lowest: compounds 3 and 2 (each within the scatter of the next); then compound 1.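

In this assay, the exchange of 2,4-dichlorophenyl for 2,3-dichlorophenyl on the amine nitrogen in a ring gives a step of a number 3 percentage points lower from compound 2 to compound 3 (within the scatter), so the two arrangements of the same atoms cannot be told apart at this position. The large step away from isopropyl is therefore not confined to one dichlorophenyl, as a number 64.3 percentage points lower from compound 1 to compound 3 (beyond the scatter) stands alongside the earlier a number 61.3 percentage points lower from compound 1 to compound 2 (beyond the scatter), and both compounds with a dichlorophenyl go the same way from compound 1. Nothing in the data gives a reason for this tolerance or for the large step from isopropyl.

The compounds shown leave open whether the large step depends on chlorine at all, a question that an unsubstituted phenyl, a methoxyphenyl or a pyridyl on the same nitrogen would address. They also leave open how compound 2 and compound 3 compare at other concentrations, as a read-out at one concentration gives only the size of the effect at that concentration.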